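An Aryl Swap on an Aromatic Nitrogen, Measured and Expected

The source may report more compounds than this note shows. Statements on the series, on what has been measured and on what is new or still open speak of the compounds shown alone.

Compound 1, `COc1cc2c(Oc3ccc(NC(=O)c4cn(-c5cc(C)ccc5C)cn4)cc3F)ccnc2cc1OCCCN1CCN(C)CC1`, gives 350 nM in a functional assay on A549 cells (Homo sapiens) for cytotoxicity, read by MTT assay, with a stated time of 72 h; on this read-out higher numbers stand for weaker inhibition and lower numbers for stronger inhibition.
Compound 2, `COc1cc2c(Oc3ccc(NC(=O)c4cn(-c5ccc(Cl)cc5)cn4)cc3F)ccnc2cc1OCCCN1CCN(C)CC1`, gives 5200 nM in this assay.
Compound 3, `COc1cc2c(Oc3ccc(NC(=O)c4cn(-c5cc(C)ccc5C)cn4)cc3F)ccnc2cc1OCCCN1CCCCC1`, gives 510 nM in this assay.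

Three measured compounds share one pattern and differ at two points. The change from compound 1 to compound 2 is 4-chlorophenyl in place of 2,5-dimethylphenyl on an aromatic nitrogen, and it produced a 15-fold higher number from compound 1 to compound 2 (1.17 log units; beyond the scatter). The change from compound 1 to compound 3 is piperidin-1-yl in place of 4-methylpiperazin-1-yl on a saturated chain carbon, three bonds along the chain from an oxygen on an aromatic ring, and it produced only a 1.5-fold higher number from compound 1 to compound 3 (0.16 log units; within the scatter), so the two cores behave alike in this assay as far as these numbers show.

Compound 4, `COc1cc2c(Oc3ccc(NC(=O)c4cn(-c5ccc(Cl)cc5)cn4)cc3F)ccnc2cc1OCCCN1CCCCC1`, has not been measured. It differs from compound 3 by 4-chlorophenyl in place of 2,5-dimethylphenyl on an aromatic nitrogen. Within the data shown here, this is the same change as the one from compound 1 to compound 2; the place at which it is made is described in the same words in both pairs, and only the core differs, in the way set out for compound 1 and compound 3.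

For compound 4 the account therefore expects a step of about a 14-fold higher number from compound 3 to compound 4 (1.14 log units; beyond the scatter) from compound 3, resting on a 15-fold higher number from compound 1 to compound 2 (1.17 log units; beyond the scatter) seen with the other core. On that basis compound 4 is estimated at 7000 nM in this assay, with an expected range from 2500 nM to 20000 nM.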

Compound 4, half-maximal inhibitory concentration: 6560 nM
Compound 4: middle estimate off by 1.1-fold (0.03 log units), on the high side, within the range that was stated.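

In this assay, the aryl swap on the aromatic nitrogen gives a 13-fold higher number from compound 3 to compound 4 (1.11 log units; beyond the scatter), and its size holds from one core to the other: the same change on two cores in this assay, a 15-fold higher number (1.17 log units; beyond the scatter) from compound 1 to compound 2 and a 13-fold higher number (1.11 log units; beyond the scatter) from compound 3 to compound 4, 1.2-fold (0.06 log units) apart, within the scatter of two such steps. The swap of 4-methylpiperazin-1-yl for piperidin-1-yl, read with the 4-chlorophenyl group in place, gives a 1.3-fold higher number from compound 2 to compound 4 (0.10 log units; within the scatter), and it stays as small as it was with the 2,5-dimethylphenyl group: the same change on two cores in this assay, a 1.5-fold higher number (0.16 log units; within the scatter) from compound 1 to compound 3 and a 1.3-fold higher number (0.10 log units; within the scatter) from compound 2 to compound 4, 1.2-fold (0.06 log units) apart, within the scatter of two such steps. Within these four compounds, then, each change keeps its size whichever form the other place takes, but this is a single set of two aryl groups and two amines in one assay, so it does not show that the step would carry over to other cores, and it does not explain why the numbers move as they do.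

The compounds shown leave open whether the large step follows the loss of the two methyl groups or the arrival of the chlorine, which an unsubstituted phenyl or a 2,5-dichlorophenyl group on the same nitrogen could help to separate. They also leave open whether the step would keep its size with a morpholin-4-yl group or a longer chain on the oxygen of the shared core.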